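Swapping the nitrophenyl pattern on a dihydropyridine core

A few compounds are considered here, and "the series" means these few. Any claim that something is new, unique, unknown or untested is made for them only; others in the source may bear on it.

Measured compounds:
- compound 1, `CCCCC1=C(C(=O)OCC)C(c2cccc([N+](=O)[O-])c2)C(C(=O)OCC)=C(C)N1`, 20 nM
- compound 2, `CCOC(=O)C1=C(C)NC(COC(=O)c2ccccc2)=C(C(=O)OCC)C1c1cccc([N+](=O)[O-])c1`, 210 nM
- compound 3, `C=CCOC(=O)C1=C(C)NC(C)=C(C(=O)OC)C1c1ccccc1[N+](=O)[O-]`, 8 nM

All three were tested in a functional assay on HEK293 cells for antagonist activity at Voltage-dependent L-type calcium channel subunit alpha-1C (Oryctolagus cuniculus), read by FLIPR; a lower number here means a stronger inhibitor, a higher number a weaker inhibitor. Compound 3 gives the lowest number of the three, with compound 1 the nearest and compound 2 the furthest away; both gaps lie beyond the scatter, so compound 3 counts as the strongest inhibitor of the measured set in this assay.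

The next compound, compound 4 with structure `C=CCOC(=O)C1=C(C)NC(C)=C(C(=O)OC)C1c1cccc([N+](=O)[O-])c1`, keeps every atom of compound 3 and rearranges only the aromatic ring: 3-nitrophenyl in place of 2-nitrophenyl on a saturated ring carbon. In plain words, a 3-nitrophenyl replaces a 2-nitrophenyl on a saturated ring carbon of the shared core.

Among the measured compounds shown here, only one measured step exists, an 11-fold higher number from compound 1 to compound 2 (1.02 log units; beyond the scatter), and it concerns the chain at a different position, not the nitrophenyl group. It therefore says nothing directly about the change from compound 3 to compound 4. Compounds 1 and 2 both already carry the 3-nitrophenyl group and, in this assay, compound 1 gives 20 nM while compound 3 with the 2-nitrophenyl gives 8 nM, but their esters differ too, so the comparison is indirect.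

Given this, the step of a 2.5-fold higher number from compound 3 to compound 4 (0.40 log units; beyond the scatter) is expected to be modest, toward a somewhat higher number. Compound 4 is estimated at 20 nM, within a range from 5 nM to 80 nM.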

Compound 4, half-maximal inhibitory concentration: 15 nM
Beside the measured number, compound 4's estimate is 1.3-fold (0.12 log units) above it; measured number inside the range.
By their numbers in this assay, from the lowest: compounds 3, 4 and 1 (each within the scatter of the next, the first and the last beyond it); then compound 2.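

Among the compounds shown here, this is the first pair in the set that differs only in the nitrophenyl group on the saturated ring carbon, so it isolates that change, with both esters and both methyl groups held fixed. In this assay, the swap of 2-nitrophenyl for 3-nitrophenyl gives a 1.9-fold higher number from compound 3 to compound 4 (0.27 log units; within the scatter), which means that compound 3 and compound 4 cannot be told apart here and that, on this core, both placements of the nitro group are compatible with low-nanomolar inhibition. Nothing available on these compounds explains why the two placements read alike.

The compounds shown leave open whether the nitro group is needed at all, since every ring at this position carries one, and a plain phenyl, a chlorophenyl or a cyanophenyl would test that directly. They also leave open whether the same swap would read alike with the ethyl esters and the longer chain or benzoyloxy-bearing chain of compound 1 and compound 2, where the surrounding groups are different.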